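The source may report more compounds than this note shows. Statements on the series, on what has been measured and on what is new or still open speak of the compounds shown alone.

Measured so far in a functional assay on the whole organism (B cells) with Mus musculus as the target; a higher number here means a larger maximal response, a lower number a smaller maximal response:
- compound 1 `COc1ccc(Cn2c(=O)n(C3OC(CO)[C@@H](O)[C@H]3O)c3nc(N)nc(O)c32)cc1`: 44%
- compound 2 `CCCCCCCCCCn1c(=O)n(C2OC(CO)[C@@H](O)[C@H]2O)c2nc(N)nc(O)c21`: 0%
- compound 3 `Cn1c(=O)n(C2OC(CI)[C@@H](O)[C@H]2O)c2nc(N)nc(O)c21`: 32%

Compound 3 stands second of the three in this assay. Its nearest neighbour is compound 1, which gives a higher reading, beyond the scatter; its furthest is compound 2, which gives a lower reading, by a margin also beyond the scatter. Among the compounds with values here, the one step between measured compounds that differ in a single place is a number 44 percentage points lower from compound 1 to compound 2 (beyond the scatter), a change on the saturated chain carbon bound to the aromatic nitrogen, where nonyl replaces 4-methoxyphenyl.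

Compound 4 `Cn1c(=O)n(C2OC(CO)[C@@H](O)[C@H]2O)c2nc(N)nc(O)c21` is not yet measured. It differs from compound 3 as follows: hydroxy in place of iodo on a saturated chain carbon bound to a saturated ring carbon. Cut one bond further out, this reads iodomethyl to hydroxymethyl.

Within the data shown here, no measured step touches this part of the shared core: the only step on record concerns the substituent at the aromatic nitrogen, not the saturated chain carbon bound to the saturated ring carbon. There is therefore no basis for expecting a shift beyond the scatter in this assay, and the step is estimated as a number 3 percentage points higher from compound 3 to compound 4 (within the scatter), essentially flat. Compound 4 is accordingly expected to give about 35% in this assay, with a range from 12% to 58%; the width reflects the absence of any comparable step.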

Compound 4, largest response reached (reported as maximal response), in percent of the reference or control that the assay uses: 99%
Beside the measured number, compound 4's estimate is 64 percentage points below it, outside the stated range (above it).
By their numbers in this assay, from the lowest: compound 2; then compound 3; then compound 1; then compound 4.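

Position on the saturated chain carbon bound to a saturated ring carbon: hydroxy in place of iodo gives a number 67 percentage points higher from compound 3 to compound 4 (beyond the scatter) in this assay, so this position, untouched by any earlier step, strongly affects the response. Within the data shown here, at the saturated chain carbon bound to an aromatic nitrogen, hydrogen in place of 4-methoxyphenyl gives a number 55 percentage points higher from compound 1 to compound 4 (beyond the scatter) and hydrogen in place of nonyl gives a number 99 percentage points higher from compound 2 to compound 4 (beyond the scatter), which adds to the single earlier step here and shows that, of the three groups, hydrogen at this carbon gives the largest maximal response in this assay, with the steps to 4-methoxyphenyl and nonyl both beyond the scatter. No measurement in hand accounts for either change.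

Still open, going by these compounds, is whether the gain belongs to hydroxy itself, which an amine, a methoxy group or a carboxylic acid at the same carbon would help to test, along with chloro or fluoro in place of iodo. Also open, on these data alone, is how far a chain on the aromatic nitrogen can grow from hydrogen towards nonyl, for instance with propyl or butyl, before the response falls.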